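Replacing tert-butyl with dimethylamino on the para-substituted phenyl

The source may report more compounds than this note shows. Statements on the series, on what has been measured and on what is new or still open speak of the compounds shown alone.

The account covers two measured compounds that share one core and a third not yet tested. Compound 1 `COc1cc(-c2ccnc3c(-c4ccc(C)cc4)cnn23)cc(OC)c1OC` was examined in a functional assay on A549 cells (Homo sapiens) for inhibition, read by CCK-8 assay, with a stated time of 48 h; a higher number here means a weaker inhibitor, a lower number a stronger inhibitor. In this assay compound 1 gives only a limit of the assay, > 10000 nM. Compound 2 `COc1cc(-c2ccnc3cc(-c4ccc(C(C)(C)C)cc4)nn23)cc(OC)c1OC` likewise reaches only a limit in this assay, > 10000 nM. Within the data shown here, both values sit at the limit of > 10000 nM in this assay, at which 2 of the 2 values shown sit, so no numerical step between them can be stated, and compound 2 stands at that limit rather than at a number. Compound 3 `COc1cc(-c2ccnc3cc(-c4ccc(N(C)C)cc4)nn23)cc(OC)c1OC` differs from compound 2 in one place: dimethylamino in place of tert-butyl on an aromatic carbon. Among the measured compounds shown here, no measured step resembles this change, so the expectation rests on the standing of compound 2 alone. Compound 3 is expected to stay close to the limit, with an expected step of an at least 1.2-fold lower number from compound 2 to compound 3 (0.09 log units; that floor lies within the scatter) not clearly beyond the scatter. In this assay compound 3 is therefore estimated at 8000 nM, within a range from 1500 nM to 30000 nM.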

Compound 3, half-maximal inhibitory concentration: 1100 nM
The estimate for compound 3 lay 7.3-fold (0.86 log units) above the measured number; measured number below the stated range.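

Swapping 4-(tert-butyl)phenyl for 4-(dimethylamino)phenyl gives an at least 9.0-fold lower number from compound 2 to compound 3 (0.95 log units; beyond the scatter) in this assay, so this place on the aromatic ring, which had shown only limits so far, can separate a stronger inhibitor from a weaker one. The group that enters here is smaller by the count of heavy atoms and brings a nitrogen, and with it compound 3 gives a number rather than a limit. The full size of the step stays unknown, and the step can be stated only as a floor: the limit of > 10000 nM in this assay, at which 2 of the 3 values shown sit.

The compounds shown do not tell whether the nitrogen itself matters, and a methoxy group, a morpholine or a primary amine at the same place would bear on that. Among these compounds, compound 1 differs from compound 3 in more than one place, so no step joins them.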